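Amide aryl swap from compound 2 to compound 3

This account rests on a few compounds, and the source may have more. Where it says the series, first, only, none or still open, it means among the compounds named here.

Measured compounds:
compound 1 `CCCCCN1C(=O)C/C(=C\c2cccc(C(=O)Nc3ccc(C)cc3)c2)C1=O`: > 100000 nM
compound 2 `Cc1ccc(NC(=O)c2cccc(/C=C3\CC(=O)N(c4ccccc4)C3=O)c2)cc1C`: > 100000 nM

Both readings are limits of an ADME assay on HCT-116 cells (Homo sapiens) for cytotoxicity, read by MTT assay, with a stated time of 72 h (a higher number here means a weaker inhibitor, a lower number a stronger inhibitor), rather than numbers. Compound 2 stands at that limit. Taken together, the two readings amount to the limit of > 100000 nM in this assay, at which 2 of the 2 values shown sit; no step between measured compounds can be sized from them.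

Compound 3 `COc1ccc(NC(=O)c2cccc(/C=C3\CC(=O)N(c4ccccc4)C3=O)c2)c(C)c1` carries 4-methoxy-2-methylphenyl in place of 3,4-dimethylphenyl on an amide-type nitrogen. Going by the values given here, with no measured step to lean on, the expectation in this assay is for no change beyond the usual scatter, and most likely another limit reading. The estimated step that the limit leaves unreadable from compound 2 to compound 3 is therefore expected to be flat. For compound 3 the expected value is 150000 nM, within 50000 nM to 500000 nM.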

Compound 3, half-maximal inhibitory concentration: > 100000 nM
Compound 3: no number, only a limit; the forecaster's own chance of this, stated with the estimate: 85%; the middle value lies beyond the limit too.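

Compound 2 and compound 3 both give only a limit in this assay, so no step between them can be read: the limit of > 100000 nM in this assay, at which 3 of the 3 values shown sit.

The compounds shown leave open how far compound 1, compound 2 and compound 3 actually differ in this assay.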